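Nitro in Place of Hydrogen on the Benzamide of Compound 1

The source may report more compounds than this note shows. Statements on the series, on what has been measured and on what is new or still open speak of the compounds shown alone.

Measured compounds:
compound 1 `CN(C(=O)c1ccccc1)c1ccc2[nH]c(-c3n[nH]c4ccccc34)cc2n1` gives 10600 nM
compound 2 `CN(C(=O)CCc1ccccc1)c1ccc2[nH]c(-c3n[nH]c4ccccc34)cc2n1` gives 11200 nM
compound 3 `COc1cccc(C(=O)N(C)c2ccc3[nH]c(-c4n[nH]c5ccccc45)cc3n2)c1` gives 14200 nM

In a functional assay on HCT-116 cells (Homo sapiens) for antiproliferative activity, read by MTT assay, with a stated time of 72 h (on this read-out higher numbers stand for weaker inhibition and lower numbers for stronger inhibition), compound 1 stands at the lowest of the three numbers, yet compound 2 and compound 3 both sit within the scatter of it. Compound 4 `CN(C(=O)c1ccc([N+](=O)[O-])cc1)c1ccc2[nH]c(-c3n[nH]c4ccccc34)cc2n1` differs from compound 1 by nitro in place of hydrogen on an aromatic carbon, which read one bond further out is phenyl to 4-nitrophenyl. The step that bears most on it is a 1.3-fold higher number from compound 1 to compound 3 (0.13 log units; within the scatter), where a group likewise entered the same ring, and a 1.1-fold higher number from compound 1 to compound 2 (0.02 log units; within the scatter) also left the number where it was. As neither moved beyond the scatter, no step beyond the scatter is expected here. Compound 4 is therefore estimated at 11000 nM, with a range from 5000 nM to 25000 nM, an expected 1.0-fold higher number from compound 1 to compound 4 (0.02 log units; within the scatter).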

Compound 4, half-maximal inhibitory concentration: 19900 nM
Estimate against measurement, compound 4: 1.8-fold (0.26 log units) below; the measured number falls inside the stated range.
By their numbers in this assay, from the lowest: compounds 1, 2, 3 and 4 (each within the scatter of the next).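

In this assay the change to 4-nitrophenyl gives a 1.9-fold higher number from compound 1 to compound 4 (0.27 log units; within the scatter) and so stays within the scatter, even with three heavy atoms entering para to a large group. Set against the other groups on the carbonyl carbon, it gives a 1.4-fold higher number from compound 3 to compound 4 (0.15 log units; within the scatter) and a 1.8-fold higher number from compound 2 to compound 4 (0.25 log units; within the scatter) and so all four compounds remain within the scatter of one another. No available measurement bears on what lies behind these numbers. Still open, going by these compounds, is whether an amine or a carboxylic acid on this ring, or a longer chain on the carbonyl carbon, would move the number beyond the scatter.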